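Mirror-image pair of a fucosidase scaffold

The compounds below may be only part of what the source reports. "The series", "measured", "known", "first", "only" and "open" are said of these compounds alone.

Measured: compound 3 `Cc1ccc([C@@]2(CO)NC[C@H](O)[C@H]2O)cc1`, 3.3%; compound 1 `COc1ccc([C@]2(CO)NC[C@@H](O)[C@@H]2O)cc1`, 2.7%; compound 2 `OC[C@@]1(c2ccc(O)cc2)NC[C@@H](O)[C@@H]1O`, 0%.

In an assay on isolated protein for inhibition of tissue alpha-L-fucosidase (Bos taurus), tested at 1000 uM (on this read-out higher numbers stand for more inhibition at the one concentration tested (going by the name of the read-out) and lower numbers for less inhibition), compound 3 gives the highest of the three numbers, yet its gaps to compound 1 and compound 2 lie within the scatter, so no order among them can be claimed. Compound 4 `Cc1ccc([C@]2(CO)NC[C@@H](O)[C@@H]2O)cc1` differs from compound 3 only in configuration: the two compounds have the same atoms and bonds and differ only in configuration as drawn: 3 of 3 stereo elements differ (all stereocentres are inverted: mirror images); a stereocentre at a saturated ring carbon is drawn S in compound 3 and R in compound 4; a stereocentre at a saturated ring carbon is drawn S in compound 3 and R in compound 4; a stereocentre at a saturated ring carbon is drawn S in compound 3 and R in compound 4. Within the data shown here, no measured step inverts the stereocentres, so none bears on this change directly; the one measured step, a number 2.7 percentage points lower from compound 1 to compound 2 (within the scatter), concerns a different change and is itself within the scatter. Every measured compound sits near the bottom of the scale, and compound 4 is therefore expected to do likewise, with a number 0.3 percentage points lower from compound 3 to compound 4 (within the scatter) amounting to no step beyond the scatter. Compound 4 is estimated at 3%, within 0% to 12%.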

Compound 4, a percentage reported as inhibition, at one concentration (the size of the read-out at that concentration, not a potency): 0%
Estimate against measurement, compound 4: 3 percentage points above; low and high end bracket the measured number.
By their numbers in this assay, from the lowest: compounds 2, 4, 1 and 3 (each within the scatter of the next).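

Inverting all three stereocentres gives a number 3.3 percentage points lower from compound 3 to compound 4 (within the scatter) in this assay, so this read-out does not separate the two mirror images, and the step bears on configuration alone: the fact that compounds 3 and 4 differ only in the configuration as drawn. At the aromatic carbon, methyl in place of hydroxy gives no change at the digits printed from compound 2 to compound 4 (within the scatter), while methyl in place of methoxy gives a number 2.7 percentage points lower from compound 1 to compound 4 (within the scatter), so neither change separates compound 4 from its partner.

From the compounds shown here alone, what stays open is whether either mirror-image form would show clear inhibition with an amine or a carboxylic acid at that aromatic carbon.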